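This account rests on a few compounds, and the source may have more. Where it says the series, first, only, none or still open, it means among the compounds named here.

Compound 1, `Cc1nc(N(C)C(=O)NC(=O)c2c(F)cccc2F)sc1C(=O)N/N=C/c1ccccc1C(F)(F)F`, gives 1.11 ug/mL in a functional assay on HepG2 cells (Homo sapiens) for inhibition, read by MTT assay, with a stated time of 72 h (a higher number here means a weaker inhibitor, a lower number a stronger inhibitor), the lowest of the two numbers measured there. Within the data shown here, its only measured neighbour is compound 2, `CN(C(=O)NC(=O)c1c(F)cccc1F)c1nc(C(F)(F)F)c(C(=O)N/N=C/c2ccccc2C(F)(F)F)s1`, which gives 26.1 ug/mL; that pair shows a 24-fold higher number from compound 1 to compound 2 (1.37 log units; beyond the scatter), a change on the shared core, not on the hydrazone side of the molecule.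

Compound 3, `Cc1nc(N(C)C(=O)NC(=O)c2c(F)cccc2F)sc1C(=O)N/N=C/c1ccc(Cl)cc1`, differs from compound 1 in one place: 4-chlorophenyl in place of 2-(trifluoromethyl)phenyl on a carbon with a double bond to nitrogen. Among the measured compounds shown here, no measured step touches this part of the molecule, so the only measured step, from compound 1 to compound 2, bears on it at most indirectly, by showing that the series can move a long way on a single substitution. Without a step at the hydrazone phenyl, the safest expectation is a change that stays near the scatter, with some allowance for a larger move in either direction.

Compound 3 is therefore estimated at 1.6 ug/mL, within a range of 0.5 ug/mL to 6 ug/mL, which would mean a step of a 1.4-fold higher number from compound 1 to compound 3 (0.16 log units; within the scatter).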

Compound 3, half-maximal inhibitory concentration: > 100 ug/mL
Compound 3 gave a limit, no number; the forecaster's own chance of this, stated with the estimate: 3%; middle value at least 62-fold (1.79 log units) from the limit.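

The hydrazone side of the molecule is not a passive part of this series: 4-chlorophenyl in place of 2-(trifluoromethyl)phenyl on a carbon with a double bond to nitrogen gives an at least 90-fold higher number from compound 1 to compound 3 (1.95 log units; beyond the scatter) in this assay. Among these compounds, until this result, the only measured large step lay on the shared core, a 24-fold higher number from compound 1 to compound 2 (1.37 log units; beyond the scatter), so it is now clear that a single change on either side of the molecule can carry the number beyond the scatter. The reading for compound 3 is a limit of the assay and not a number, so the true size of this step stays unknown: the limit of > 100 ug/mL in this assay, at which 1 of the 3 values shown sits.

The change alters both the substituent on the phenyl ring and its numbered place on that ring, so the compounds shown cannot tell whether the swap of trifluoromethyl for chlorine or the shift in place accounts for the higher number. As far as these compounds go, it also remains open whether a phenyl ring with no substituent, or one carrying an amine or a carboxylic acid, would give a number close to that of compound 1 or would reach the limit seen for compound 3.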